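The compounds below may be only part of what the source reports. "The series", "measured", "known", "first", "only" and "open" are said of these compounds alone.

In a functional assay on HepG2 cells (Homo sapiens) for antiproliferative activity, read by MTT assay, with a stated time of 72 h (a higher number here means a weaker inhibitor, a lower number a stronger inhibitor), compound 2 (`COc1ncc(-c2ccc3c(c2)N(c2ccc(F)cc2)C(=O)CO3)cc1NS(=O)(=O)c1ccc(F)cc1`) gives 36400 nM and stands highest of the two exact numbers, while compound 1 (`COc1ccc(N2C(=O)COc3ccc(-c4ccc(O)cc4)cc32)cc1`) gives the lower 10800 nM in this set. Compound 3 (`O=C1COc2ccc(-c3cnc(Cl)c(NS(=O)(=O)c4ccc(F)cc4)c3)cc2N1c1ccc(F)cc1`) reaches only a limit (> 40000 nM) and gives no number. Compound 4 (`COc1ncc(-c2ccc3c(c2)N(C(C)C)C(=O)CO3)cc1NS(=O)(=O)c1ccc(F)cc1`) has isopropyl in place of 4-fluorophenyl on an amide-type nitrogen in a ring. For the measured compounds named here, the one measured step (an at least 1.0-fold higher number from compound 2 to compound 3 (0.04 log units; that floor lies within the scatter)) has its floor within the scatter and lies at another place, so it does not bear on this change. Going by the values given here, no measured step involves that nitrogen, so no shift beyond the scatter is expected in this assay and the direction stays open. The expected step is small (a 1.5-fold lower number from compound 2 to compound 4 (0.18 log units; within the scatter)) in this reading. Compound 4 is estimated at 24000 nM with an expected range of 6000 nM to 45000 nM in this assay.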

Compound 4, half-maximal inhibitory concentration: 37200 nM
For compound 4 the middle estimate is 1.6-fold (0.19 log units) below the measured one, within the range that was stated.
By their numbers in this assay, from the lowest: compound 1; then compounds 2 and 4 (each within the scatter of the next). At a limit, above all of these: compound 3.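

In this assay isopropyl in place of 4-fluorophenyl on the amide-type nitrogen in the ring gives a 1.0-fold higher number from compound 2 to compound 4 (0.01 log units; within the scatter) and so no shift at this position. For the compounds shown here, this is the first measured step at this nitrogen, and it shows that a smaller group without a ring can take the place of the aromatic one with the reading unmoved. That reading lies at the weak end of the numbers shown, and compound 3 gives only a limit: the limit of > 40000 nM in this assay, at which 1 of the 4 values shown sits. As far as these compounds go, whether an amine, a carboxylic acid or a longer chain on this nitrogen would move the number stays open. So does whether the same change would hold on the core of compound 1.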